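The source may report more compounds than this note shows. Statements on the series, on what has been measured and on what is new or still open speak of the compounds shown alone.

Measured so far in an ADME assay on HPLF cells (Homo sapiens) for cytotoxicity, with a stated time of 24 h; on this read-out lower numbers stand for higher toxicity in this test and higher numbers for lower toxicity in this test:

compound 1, `Cc1ccc(/C=C2\CCC/C(=C\c3cccc([N+](=O)[O-])c3)C2=O)cc1`: > 400000 nM.
compound 2, `COc1ccc(/C=C2\CCC/C(=C\c3cccc([N+](=O)[O-])c3)C2=O)cc1`: 354000 nM.
compound 3, `Cc1ccc(/C=C2\CCC/C(=C\c3ccc([N+](=O)[O-])cc3)C2=O)cc1`: 348000 nM.

The value of compound 1, > 400000 nM, is a limit of this assay and not a number; it sits at the limit of > 400000 nM in this assay, at which 1 of the 3 values shown sits.

Compound 1 and compound 2 differ in one place, (methoxy in place of methyl on an aromatic carbon). The step made by this change is an at least 1.1-fold lower number from compound 1 to compound 2 (0.05 log units; that floor lies within the scatter), so its true size is not pinned down; only a floor is known, and that floor lies within the scatter.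

Compound 2 and compound 3 give numbers that lie within the scatter of each other, so nothing separates them on this read-out. Compound 3 and compound 1 are built from the same atoms joined differently; the difference between the two cores is not broken down here.

Compound 4, `COc1ccc(/C=C2\CCC/C(=C\c3ccc([N+](=O)[O-])cc3)C2=O)cc1`, has not yet been measured in this assay. For the measured compounds named here, from compound 3 it differs by methoxy in place of methyl on an aromatic carbon, which is the same change, at the same place, as the one that carries compound 1 to compound 2. The step expected here is a 1.1-fold lower number from compound 3 to compound 4 (0.04 log units; within the scatter), and that expectation rests on the earlier step of an at least 1.1-fold lower number from compound 1 to compound 2 (0.05 log units; that floor lies within the scatter), read together with the value of compound 3, 348000 nM. Because one of the three values sits at the limit of > 400000 nM in this assay, at which 1 of the 3 values shown sits, a further limit rather than a number remains a real possibility. Compound 4 is accordingly expected to give 320000 nM, with a likely range from 180000 nM to 600000 nM.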

Compound 4, half-maximal cytotoxic concentration: > 400000 nM
Compound 4: a limit, no number; the forecaster's own chance of this, stated with the estimate: 25%; middle value at least 1.2-fold (0.09 log units) away from the limit.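

In this assay compound 4 gives > 400000 nM, which is a limit of the assay and not a number. Methoxy in place of methyl on an aromatic carbon, here para to a large group, gives an at least 1.1-fold higher number from compound 3 to compound 4 (0.06 log units; that floor lies within the scatter), so only a floor is known for this step and its true size remains unknown. The two readings of this change show no measured step beyond the scatter on either core, but they do not establish that it carries from one core to the other with the same size, or that its size depends on the core: the same change on two cores in this assay, an at least 1.1-fold lower number (0.05 log units; that floor lies within the scatter) from compound 1 to compound 2 and an at least 1.1-fold higher number (0.06 log units; that floor lies within the scatter) from compound 3 to compound 4; the limit leaves it open whether they differ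

The compounds shown leave open how far any of them would separate from the others at the top of the measurable range, where the read-out gives limits rather than numbers: the limit of > 400000 nM in this assay, at which 2 of the 4 values shown sit. Also open is how this assay would respond to a group outside the methyl, methoxy and nitro substituents seen here, such as an amine, a carboxylic acid or a longer chain in place of methyl or methoxy.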